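The compounds below may be only part of what the source reports. "The series", "measured", "known", "first", "only" and "open" are said of these compounds alone.

Three analogues sharing one core have been measured in a functional assay on MGC-803 cells (Homo sapiens) for inhibition, read by sulforhodamine B assay; a lower number here means a stronger inhibitor, a higher number a weaker inhibitor. Compound 1 `CCCc1ccc(NC2=CC(=O)c3c(nc4n3[C@H]3OC[C@@H](O)[C@H]3OC4)C2=O)cc1` carries a 4-propylphenyl group on an amine nitrogen and gives 1920 nM. Compound 3 `O=C1C(Nc2ccccc2F)=CC(=O)c2c1nc1n2[C@H]2OC[C@@H](O)[C@H]2OC1` carries a 2-fluorophenyl group in the same position and gives 2000 nM; the change from compound 1 to compound 3 amounted to a 1.0-fold higher number from compound 1 to compound 3 (0.02 log units; within the scatter). Compound 2 `O=C1C=C(Nc2ccc(C(F)(F)F)cc2)C(=O)c2c1nc1n2[C@H]2OC[C@@H](O)[C@H]2OC1` carries a 4-(trifluoromethyl)phenyl group and gives 2820 nM, a number that sits within the usual scatter of both compound 1 and compound 3, so the three compounds cannot be told apart by this assay.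

Compound 4 `CCOc1ccc(NC2=CC(=O)c3nc4n(c3C2=O)[C@H]2OC[C@@H](O)[C@H]2OC4)cc1` differs from compound 2 in one place: ethoxy in place of trifluoromethyl on an aromatic carbon. Going by the values given here, no measured pair reports this particular exchange. Among the compounds with values here, the only step available, from compound 1 to compound 3, swapped one substituted phenyl group for another and produced nothing beyond the scatter. On that basis the exchange of trifluoromethyl for ethoxy is expected to leave the number where the measured compounds already sit, with an expected step of a 1.3-fold lower number from compound 2 to compound 4 (0.11 log units; within the scatter) in this assay. Compound 4 is therefore estimated at 2200 nM, with a likely range from 1000 nM to 5000 nM.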

Compound 4, half-maximal inhibitory concentration: 1110 nM
For compound 4 the middle estimate is 2.0-fold (0.30 log units) above the measured one, and the stated range covers the measured number.
By their numbers in this assay, from the lowest: compounds 4, 1, 3 and 2 (each within the scatter of the next, the first and the last beyond it).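

In this assay the exchange of trifluoromethyl for ethoxy on this aromatic carbon gives a 2.5-fold lower number from compound 2 to compound 4 (0.40 log units; beyond the scatter) and so makes compound 4 a modestly stronger inhibitor than compound 2, which shows that the group carried on this phenyl ring can shift the number by more than repeat measurements would. Going by these compounds alone, the only earlier step, a 1.0-fold higher number from compound 1 to compound 3 (0.02 log units; within the scatter) when 2-fluorophenyl replaced 4-propylphenyl, gave no such sign, and the three earlier compounds could not be told apart. The exchange replaces a group with no hydrogen-bond acceptor by one with a single acceptor, but nothing measured here links that difference to the step or offers any other explanation for it.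

This single pair cannot separate the part played by the ethoxy oxygen from that of its two-carbon chain, or show whether losing the trifluoromethyl group matters as much as gaining the ethoxy group. A methoxy group, a longer butoxy chain, or a dimethylamino group on the same aromatic carbon would each test a different part of that question.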